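Furan-2-yl in Place of Hexyl on a Pyridyl Cyanoguanidine

A few compounds are considered here, and "the series" means these few. Any claim that something is new, unique, unknown or untested is made for them only; others in the source may bear on it.

Measured compounds:
compound 1 `CC(C)(C)C/N=C(/NC#N)Nc1cccnc1` — 2.5 mg/kg
compound 2 `CCCCCCC/N=C(\NC#N)Nc1cccnc1` — > 50 mg/kg

Both were examined in a functional assay on the whole organism (blood, strain Wistar-Okamoto) with Rattus norvegicus as the target, with a stated time of 5 days; on this read-out higher numbers stand for an effect only at larger amounts of compound and lower numbers for an effect already at smaller amounts. Compound 1 gives 2.5 mg/kg in this assay. For compound 2 this assay reports only a limit, > 50 mg/kg, and not a number; compound 2 therefore sits at the limit of > 50 mg/kg in this assay, at which 1 of the 2 values shown sits.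

Compound 3 `N#CN/C(=N\Cc1ccco1)Nc1cccnc1` has not yet been measured in this assay. It differs from compound 2 in one place: furan-2-yl in place of hexyl on a saturated chain carbon bound to a double-bonded nitrogen. Going by the values given here, no step between two measured compounds is given, so the size of this change can only be guessed from where compound 2 stands. Any number reported for compound 3 would already mean a move toward smaller doses, and the step of an at least 2.5-fold lower number from compound 2 to compound 3 (0.39 log units; beyond the scatter) is expected to go beyond the scatter in that direction. Compound 3 is estimated at 20 mg/kg, with a range from 5 mg/kg to 50 mg/kg.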

Compound 3, minimum effective dose: 20 mg/kg
Beside the measured number, compound 3's estimate shows no gap at the digits printed; the range from low to high includes it.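

In this assay, furan-2-yl in place of hexyl on a saturated chain carbon bound to a double-bonded nitrogen turns a limit into a readable number, and the change is an at least 2.5-fold lower number from compound 2 to compound 3 (0.39 log units; beyond the scatter). This shows that the position can carry a five-membered aromatic ring with one hetero atom and still give an effect at a dose the read-out can report. The step is only a lower bound on the change, since compound 2 is held at a limit and not at a number: the limit of > 50 mg/kg in this assay, at which 1 of the 3 values shown sits.

On these data alone, whether the ring itself or its oxygen goes with this change stays open; a phenyl or a thiophene ring at the same place would separate the two. The compounds shown also leave open whether a shorter chain such as propyl would give a reportable dose here.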